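The source may hold more compounds than are shown below. What is called first, only, known or untested is meant among the compounds shown, and "the series" means these compounds.

Measured compounds in a functional assay on BE(2)-C cells (Homo sapiens) for inhibition, read by MTT assay, with a stated time of 72 h; a higher number here means a weaker inhibitor of growth, a lower number a stronger inhibitor of growth:
compound 1 `O=S(=O)(NCCCNCc1ccccc1Cl)c1cc(C(F)(F)F)cc(C(F)(F)F)c1` gives 15000 nM
compound 2 `COc1ccc(CNCCCNS(=O)(=O)c2cc(C(F)(F)F)cc(C(F)(F)F)c2)cc1OC` gives 3600 nM
compound 3 `CN(CCCNS(=O)(=O)c1cc(C(F)(F)F)cc(C(F)(F)F)c1)Cc1ccccc1` gives 28000 nM

Of the three numbers, compound 3 has the highest, which is the weakest inhibition of growth. Compound 1 comes nearest to it, and compound 2 sits furthest away, with the lowest number of the set.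

Compound 4 `COc1ccc(CNCCCNS(=O)(=O)c2cc(C(F)(F)F)cc(C(F)(F)F)c2)cc1` is not yet measured. It differs from compound 3 in one place: (4-methoxybenzyl)amino in place of benzyl(methyl)amino on a saturated chain carbon, three bonds along the chain from a sulfonamide nitrogen. The change has two parts, and each has a measured counterpart. Undoing the methyl on the amine nitrogen is the reverse of the step of a 1.9-fold higher number from compound 1 to compound 3 (0.27 log units; within the scatter), which stayed within the scatter. Adding methoxy to the benzyl ring resembles the step of a 4.2-fold lower number from compound 1 to compound 2 (0.62 log units; beyond the scatter), a modest gain, though there two methoxy groups entered where a chlorine left, while here a single methoxy enters a ring that was unsubstituted. Putting both together, the expectation is that compound 4 will show a lower number than compound 3 in this assay, about the size of the earlier methoxy step. The estimate for compound 4 is therefore 6000 nM, within a range of 2000 nM to 18000 nM. The expected step from compound 3 to compound 4 is a 4.7-fold lower number from compound 3 to compound 4 (0.67 log units; beyond the scatter).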

Compound 4, concentration for 50% growth inhibition: 2800 nM
For compound 4 the middle estimate is 2.1-fold (0.33 log units) above the measured one, within the range that was stated.
By their numbers in this assay, from the lowest: compounds 4 and 2 (each within the scatter of the next); then compounds 1 and 3 (each within the scatter of the next).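

In this assay the exchange at this saturated chain carbon gives a 10-fold lower number from compound 3 to compound 4 (1.00 log units; beyond the scatter) and so lies beyond the scatter, which shows that this position can respond clearly, although the step joins two changes, the loss of the methyl on the amine nitrogen and the gain of a methoxy, and their shares cannot be separated here. Taking away one methoxy gives only a 1.3-fold lower number from compound 2 to compound 4 (0.11 log units; within the scatter) and stays within the scatter, so in this pair the second methoxy adds nothing that can be told from ordinary variation. A single methoxy is also enough for a gain beyond the scatter when 4-methoxyphenyl stands in place of 2-chlorophenyl, which gives a 5.4-fold lower number from compound 1 to compound 4 (0.73 log units; beyond the scatter) and matches what the two methoxy groups did in a 4.2-fold lower number from compound 1 to compound 2 (0.62 log units; beyond the scatter) in direction.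

No measurement at hand explains why these changes shift growth inhibition. Still open, as far as these compounds go, is how a hydroxy group or a fluorine on the benzyl ring would read in this assay and whether a longer chain would keep the effect of the methoxy group.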